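The source may report more compounds than this note shows. Statements on the series, on what has been measured and on what is new or still open speak of the compounds shown alone.

The measured compounds:

Compound 1 `Cc1cc(Cl)c(S(C)(=O)=O)cc1C(=O)N=C(N)N` gives 25 nM in a functional assay for inhibition of sodium/hydrogen exchanger (Oryctolagus cuniculus); a higher number here means a weaker inhibitor, a lower number a stronger inhibitor.
Compound 2 `Cc1cc(-c2ccc(F)cc2)c(S(C)(=O)=O)cc1C(=O)N=C(N)N` gives 36 nM.
Compound 3 `CS(=O)(=O)c1cc(C(=O)N=C(N)N)c(Cl)cc1Oc1cccnc1` gives 52 nM.

All three share the same core and differ only in the group that sits on one aromatic carbon of it. Compound 3 has the highest of the three numbers. Its gap to compound 2 lies within the scatter, so the two cannot be told apart by these measurements; its gap to compound 1 lies beyond the scatter, so compound 1 is the stronger inhibitor of that pair.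

Compound 4 `CS(=O)(=O)c1cc(C(=O)N=C(N)N)c(Cl)cc1Nc1ncccn1` has not yet been measured. It differs from compound 3 in one place: (pyrimidin-2-yl)amino in place of (pyridin-3-yl)oxy on an aromatic carbon. Going by the values given here, only one measured step changes a single group on the core, a 1.4-fold higher number from compound 1 to compound 2 (0.16 log units; within the scatter), and it lies within the scatter. That step alters a different group at a different place, so it bears on the present change only loosely, as a sign that a single substituent swap on this core need not move the number much. Among the compounds with values here, no measured step replaces a (pyridin-3-yl)oxy group with a (pyrimidin-2-yl)amino group, so nothing in the data points to a direction. The expectation is therefore a step within the scatter in this assay, with no direction favoured: a 1.0-fold lower number from compound 3 to compound 4 (0.02 log units; within the scatter). For compound 4 the estimate is 50 nM, with a range from 18 nM to 140 nM.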

Compound 4, half-maximal inhibitory concentration: 49 nM
Compound 4: middle estimate off by 1.0-fold (0.01 log units), on the high side, within the range that was stated.
By their numbers in this assay, from the lowest: compounds 1, 2, 4 and 3 (each within the scatter of the next, the first and the last beyond it).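

On the aromatic carbon ortho to a methylsulfonyl group and meta to a chloro group, placing (pyrimidin-2-yl)amino where (pyridin-3-yl)oxy stood gives a 1.1-fold lower number from compound 3 to compound 4 (0.03 log units; within the scatter) in this assay, so these two compounds cannot be told apart by this measurement. Going by these compounds alone, this is the first measured swap at this position, and it is not a small change in what is counted: the oxygen link becomes an amino link, the ring goes from one hetero atom to two, and a hydrogen-bond donor enters, yet no difference shows beyond the scatter. No supporting measurement is available to explain why the number stays put, and none bears on this result.

Going by these compounds, the swap changes the link and the ring together, so it remains open how each would act alone, and a (pyridin-3-yl)amino group or a (pyrimidin-2-yl)oxy group at this position would be needed to separate them. On these data alone, it is also open whether a group of a different kind here, such as a plain amine, a carboxylic acid or a longer chain, would stay within the scatter of compound 3 or move clearly away from it.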